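Swapping the Oxadiazole Tail in a Caspase-8 Inhibitor Series

This account rests on a few compounds, and the source may have more. Where it says the series, first, only, none or still open, it means among the compounds named here.

Measured compounds:
- compound 1, `CCC(C(=O)N[C@@H](CC(=O)O)C(=O)CSCc1ccccc1)n1ccnc(NCc2nc(C)no2)c1=O`: 6420 nM
- compound 2, `CCCCCCN(C)CNCC(=O)[C@H](CC(=O)O)NC(=O)C(CC)n1ccnc(NCc2nonc2C)c1=O`: > 10000 nM
- compound 3, `CCC(C(=O)N[C@H](C=O)CC(=O)O)n1ccnc(NCc2nonc2C)c1=O`: 990 nM

In an assay for inhibition of Caspase-8 (Homo sapiens) (a higher number here means a weaker inhibitor, a lower number a stronger inhibitor), compound 1 gives 6420 nM. Compound 3 gives 990 nM. Compound 2 reaches only the limit of the assay, > 10000 nM, which is a boundary rather than a number; this is noted as the limit of > 10000 nM in this assay, at which 1 of the 3 values shown sits. Among the numbers shown, compound 1 has the highest, and its nearest neighbour is compound 3, which sits well below it.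

The new compound, compound 4, `CCC(C(=O)N[C@@H](CC(=O)O)C(=O)CSCc1ccccc1)n1ccnc(NCCCOC)c1=O`, differs from compound 1 at the far end of the molecule: 2-methoxyethyl in place of 3-methyl-1,2,4-oxadiazol-5-yl on a saturated chain carbon bound to a nitrogen on an aromatic ring. Of the measured steps, only one exists, an at least 10-fold lower number from compound 2 to compound 3 (1.00 log units; beyond the scatter), and it concerns the carbonyl end of the molecule, not the chain carbon bound to the ring nitrogen where compound 4 is changed. Going by the values given here, no measured pair therefore speaks directly to this swap.

With nothing to guide the direction, the estimate for compound 4 is a number close to that of compound 1, with a 1.1-fold higher number from compound 1 to compound 4 (0.04 log units; within the scatter) expected to stay within the scatter. Compound 4 is thus estimated at 7000 nM, in a range from 2500 nM to 20000 nM.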

Compound 4, half-maximal inhibitory concentration: 7650 nM
Estimate against measurement, compound 4: 1.1-fold (0.04 log units) below, and the stated range covers the measured number.
By their numbers in this assay, from the lowest: compound 3; then compounds 1 and 4 (each within the scatter of the next). At a limit, above all of these: compound 2.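

In this assay, replacing 3-methyl-1,2,4-oxadiazol-5-yl with 2-methoxyethyl, on a saturated chain carbon bound to a nitrogen on an aromatic ring, gives a 1.2-fold higher number from compound 1 to compound 4 (0.08 log units; within the scatter), so this measurement does not separate the two compounds. Going by these compounds alone, this is the first measured step at this end of the molecule, and it shows that, in the setting of compound 1, one five-membered aromatic ring with 3 hetero atoms can give way to a chain with no ring, and with 1 hydrogen-bond acceptor instead of 3, without a shift beyond the scatter. Nothing measured for these compounds accounts for this result.

The compounds shown leave open whether this position would tolerate other kinds of group, such as an amine, a carboxylic acid or a longer chain, as it tolerates 2-methoxyethyl. They also leave open whether the same swap would give a similar result in compound 3, which has a different carbonyl end and a different oxadiazole tail from compound 1.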